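The compounds below may be only part of what the source reports. "The series", "measured", "known", "first", "only" and "open" are said of these compounds alone.

In a functional assay on HepG2 cells (Homo sapiens) for inhibition, read by MTT assay, with a stated time of 72 h, tested at 30 uM (a higher number here means more inhibition of growth at the concentration tested, a lower number less inhibition of growth), compound 2 (`C=CCc1cc(O)c(O)c(CN2CCC(CCO)CC2)c1`) gives 2.5%, within the scatter of compound 3 (`C=CCc1ccc(OCc2cn(-c3cccc(C#N)c3)nn2)c(O)c1`) at 2.3%, and far short of compound 1 (`C=CCc1cc(O)c(O)c(CN2CCC(C)CC2)c1`) at 57.6%. Compound 4 (`C=CCc1cc(O)c(O)c(CN2CCC(CO)CC2)c1`) differs from compound 2 by hydroxy in place of hydroxymethyl on a saturated chain carbon bound to a saturated ring carbon: 2-hydroxyethyl to hydroxymethyl. For the measured compounds named here, one measured step bears on this place, a number 55.1 percentage points lower from compound 1 to compound 2 (beyond the scatter), a large loss on going to the hydroxy-bearing chain. Going by the values given here, compound 4 still carries a hydroxy, and no measured compound has its chain, so only a small upward step is expected in this assay, possibly none beyond the scatter. The expected change is a number 9.5 percentage points higher from compound 2 to compound 4 (within the scatter). Compound 4 is estimated at 12%, with an expected range of 0% to 35%.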

Compound 4, percent growth inhibition at one concentration: 4.7%
Compound 4: middle estimate off by 7.3 percentage points, on the high side; the measured number falls inside the stated range.
By their numbers in this assay, from the lowest: compounds 3, 2 and 4 (each within the scatter of the next); then compound 1.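

In this assay shortening 2-hydroxyethyl to hydroxymethyl changes little (a number 2.2 percentage points higher from compound 2 to compound 4 (within the scatter)), so these two chains are not told apart here. The large loss also appears with the shorter chain (a number 52.9 percentage points lower from compound 1 to compound 4 (beyond the scatter)), so among these compounds it is not confined to 2-hydroxyethyl but holds for both hydroxy-bearing chains. No evidence on the cause is available.

Open, from the compounds shown here alone, is whether a hydroxy at this place is needed for the loss at all. A methoxy, an amine or a carboxylic acid at the chain end, or a longer chain without hydroxy, could separate the effect of the hydroxy from that of chain length.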